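Extending the sulfonamide nitrogen substituent in NAMPT activators

This account rests on a few compounds, and the source may have more. Where it says the series, first, only, none or still open, it means among the compounds named here.

Compounds measured in an assay on isolated protein for activation of Nicotinamide phosphoribosyltransferase (Homo sapiens) (on this read-out lower numbers stand for an effect already at smaller amounts and higher numbers for an effect only at larger amounts of compound), so far:
- compound 1, `NS(=O)(=O)c1ccc(NC(=O)NCc2ccncc2)cc1`: 14300 nM
- compound 2, `CNS(=O)(=O)c1ccc(NC(=O)NCc2ccncc2)cc1`: 3230 nM

Among the compounds with values here, compound 2 gives the lowest of the two numbers; the nearest is compound 1, which sits a good way behind it, and the only step measured, a 4.4-fold lower number from compound 1 to compound 2 (0.65 log units; beyond the scatter), is the one that takes the sulfonamide nitrogen from unsubstituted to methylated. Compound 3, `O=C(NCc1ccncc1)Nc1ccc(S(=O)(=O)NCc2ccccc2)cc1`, has not yet been measured. It differs from compound 2 by phenyl in place of hydrogen on a saturated chain carbon bound to a sulfonamide nitrogen, so it carries the same site one bond further out than the step already seen. That step is the only one that bears on it, and it was modest. Nothing here shows whether a larger group on this nitrogen keeps helping, so the expectation is a small further decrease or none beyond the scatter. Compound 3 is therefore estimated at 1800 nM, within 500 nM to 6000 nM, meaning an expected step of a 1.8-fold lower number from compound 2 to compound 3 (0.25 log units; within the scatter).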

Compound 3, half-maximal effective concentration: 102 nM
Compound 3: middle estimate off by 18-fold (1.25 log units), on the high side; measured number outside the range, below it.
By their numbers in this assay, from the lowest: compound 3; then compound 2; then compound 1.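

In this assay, the sulfonamide nitrogen proves able to take far more than a methyl: going from methyl to benzyl brings a 32-fold lower number from compound 2 to compound 3 (1.50 log units; beyond the scatter) and so outruns the modest gain seen with methyl alone. Measured from the unsubstituted nitrogen, benzyl brings a 140-fold lower number from compound 1 to compound 3 (2.15 log units; beyond the scatter) in all. The number falls with each larger group across these three compounds, with none going against that order, but no independent data explain the size of the benzyl step.

Going by these compounds, it remains open whether the aromatic ring itself matters, or mainly the added bulk, which a cyclohexylmethyl group or a longer chain such as phenethyl would help to separate. Also open, on these data alone, is how a chlorine atom or a methoxy group on the new phenyl would shift the number.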